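Sulfonamide-Amine Series: Bromobenzyl Swap on Compound 1

The compounds below may be only part of what the source reports. "The series", "measured", "known", "first", "only" and "open" are said of these compounds alone.

Measured so far in a functional assay on MIA PaCa-2 cells (Homo sapiens) for inhibition, read by MTT assay, with a stated time of 72 h; on this read-out higher numbers stand for weaker inhibition of growth and lower numbers for stronger inhibition of growth:
Compound 1 `COc1ccc(CNCCCNS(=O)(=O)c2cc(C(F)(F)F)cc(C(F)(F)F)c2)cc1OC` gives 2800 nM.
Compound 2 `CCCCc1ccc(S(=O)(=O)NCCCCCCNCc2ccc(Br)cc2)cc1` gives 5700 nM.
Compound 3 `O=S(=O)(NCCCCCCNCc1ccc(Br)cc1)c1ccc2c(c1)OCC2` gives 13000 nM.

Compound 1 carries the lowest number of the three; compound 2 lies beyond the scatter above it, and compound 3 further still. Both compound 2 and compound 3 already hold the 4-bromobenzyl amine, but on a different chain and with other sulfonyl aryl groups, so no single-change comparison exists for the swap itself.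

Compound 4 `O=S(=O)(NCCCNCc1ccc(Br)cc1)c1cc(C(F)(F)F)cc(C(F)(F)F)c1` differs from compound 1 in one place: 4-bromophenyl in place of 3,4-dimethoxyphenyl on a saturated chain carbon bound to an amine nitrogen. The bis(trifluoromethyl)phenyl sulfonamide and the three-carbon chain are retained.

In this assay the step from compound 1 to compound 4 is expected to be small, most likely toward a slightly higher number, and possibly within the scatter: a 1.4-fold higher number from compound 1 to compound 4 (0.15 log units; within the scatter). Compound 4 is therefore estimated at 4000 nM, with a range from 1500 nM to 11000 nM.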

Compound 4, concentration for 50% growth inhibition: 2300 nM
Beside the measured number, compound 4's estimate is 1.7-fold (0.24 log units) above it; measured number inside the range.
By their numbers in this assay, from the lowest: compounds 4 and 1 (each within the scatter of the next); then compound 2; then compound 3.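

For the compounds shown here, on a saturated chain carbon bound to an amine nitrogen, 4-bromophenyl in place of 3,4-dimethoxyphenyl gives a 1.2-fold lower number from compound 1 to compound 4 (0.09 log units; within the scatter) in this assay as the first single-place comparison. At this position, the two methoxy groups can therefore give way to a bromine with no step beyond the scatter. No evidence on the cause of this outcome is at hand.

On these data alone, whether 4-chlorophenyl or unsubstituted phenyl would read alike at this position remains open. So does whether the same swap would read alike on the longer chain of compound 2 and compound 3.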